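This account rests on a few compounds, and the source may have more. Where it says the series, first, only, none or still open, it means among the compounds named here.

Working notes on the series. In a functional assay on NCI-H1975 cells (Homo sapiens) for inhibition, read by MTT assay, with a stated time of 72 h (a lower number here means a stronger inhibitor, a higher number a weaker inhibitor), compound 1 (`FC(F)(F)c1ccc(CSc2nc(Sc3ncccn3)cc(C(F)(F)F)n2)cc1`), with pyrimidin-2-yl on a sulfur, gives 14000 nM. Compound 2 (`FC(F)(F)c1ccc(CSc2nc(Sc3nnnn3-c3ccccc3)cc(C(F)(F)F)n2)cc1`), with 1-phenyl-1H-tetrazol-5-yl at that place, gives 24300 nM, and the two are not separated: a 1.7-fold higher number from compound 1 to compound 2 (0.24 log units; within the scatter). Compound 3 (`FC(F)(F)c1ccc(CSc2nc(Sc3nncs3)cc(C(F)(F)F)n2)cc1`), with 1,3,4-thiadiazol-2-yl, gives 2270 nM, the lowest of the three numbers and the strongest inhibitor so far, as shown by a 6.2-fold lower number from compound 1 to compound 3 (0.79 log units; beyond the scatter) and an 11-fold lower number from compound 2 to compound 3 (1.03 log units; beyond the scatter).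

Compound 4 (`FC(F)(F)c1ccc(CSc2nc(SC3=NCCS3)cc(C(F)(F)F)n2)cc1`) keeps the shared core and changes only the group on this sulfur: a group of 5 heavy atoms (3 carbon, 1 nitrogen, 1 sulfur; one five-membered non-aromatic ring with 2 hetero atoms) in place of a group of 5 heavy atoms (2 carbon, 2 nitrogen, 1 sulfur; one five-membered aromatic ring with 3 hetero atoms), on a sulfur. Within the data shown here, no measured compound carries a non-aromatic ring at this place, so the direction of the step rests on limited evidence. Both other groups measured here sit above compound 3, by the two steps of a 6.2-fold lower number from compound 1 to compound 3 (0.79 log units; beyond the scatter) and an 11-fold lower number from compound 2 to compound 3 (1.03 log units; beyond the scatter), and these set the likely scale. A modest rise is therefore expected rather than a further drop, with compound 3 kept as the reference point. The expected change is a 3.1-fold higher number from compound 3 to compound 4 (0.49 log units; beyond the scatter), towards weaker inhibition. For compound 4 the estimated value in this assay is 7000 nM, with an expected range of 2000 nM to 25000 nM.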

Compound 4, half-maximal inhibitory concentration: 24200 nM
Estimate against measurement, compound 4: 3.5-fold (0.54 log units) below; the measured number falls inside the stated range.
By their numbers in this assay, from the lowest: compound 3; then compounds 1, 4 and 2 (each within the scatter of the next).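

In this assay, the non-aromatic ring does not hold the level of the 1,3,4-thiadiazol-2-yl group (an 11-fold higher number from compound 3 to compound 4 (1.03 log units; beyond the scatter)), even though the two groups have the same count of heavy atoms, so that count alone does not set the number at this place on a sulfur. The non-aromatic ring is also not separated from the much larger tetrazole group (a 1.0-fold lower number from compound 2 to compound 4 (0.00 log units; within the scatter)) or from the six-membered aromatic ring (a 1.7-fold higher number from compound 1 to compound 4 (0.24 log units; within the scatter)), so an aromatic ring alone is not enough for a low number here: compounds 1 and 2 both carry one and go against that reading, leaving compound 3 as the only strongest inhibitor among the four. No measurement shown here accounts for the gap between compound 3 and compound 4.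

Still open, going by these compounds, is whether the low number belongs to the 1,3,4-thiadiazol-2-yl group specifically or would extend to a close aromatic relative such as 1,3,4-oxadiazol-2-yl, with oxygen in place of the ring sulfur. On these data alone, it is also open how a group of a different kind on this sulfur, such as a simple amine-bearing chain or a carboxylic acid, would compare.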